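The compounds below may be only part of what the source reports. "The series", "measured", "known", "first", "only" and "open" are said of these compounds alone.

Measured so far:
- compound 1 `CCCCCc1ccc(NS(=O)(=O)c2ccc(N3CCNC3=O)cc2)cc1`: in a functional assay on M21 cells (Homo sapiens) for antiproliferative activity, read by sulforhodamine B assay, with a stated time of 48 h (a higher number here means a weaker inhibitor, a lower number a stronger inhibitor), compound 1 gives 870 nM
- compound 2 `O=C1NCCN1c1ccc(S(=O)(=O)Nc2ccc(F)c(F)c2)cc1`: in this assay compound 2 gives 220 nM

Compound 2 holds the lowest number of the two; compound 1 stands at a higher number, beyond the scatter. Compound 3 `O=C1NCCN1c1ccc(S(=O)(=O)Nc2cccc(Cl)c2)cc1` is not yet measured. Its change from compound 2: 3-chlorophenyl in place of 3,4-difluorophenyl on a sulfonamide nitrogen. Going by the values given here, no step between measured compounds is available, so the size of this change cannot be read from the series; in this assay a step within the scatter, or a modest move toward a higher number, is expected. For compound 3 the estimate in this assay is 350 nM, range 120 nM to 1000 nM. The expected step is a 1.6-fold higher number from compound 2 to compound 3 (0.20 log units; within the scatter).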

Compound 3, half-maximal inhibitory concentration: 25 nM
Compound 3: the middle estimate sits 14-fold (1.15 log units) above what was measured, and the stated range ends above it.
By their numbers in this assay, from the lowest: compound 3; then compound 2; then compound 1.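

Going by these compounds alone, the aryl group on the sulfonamide nitrogen is the first place where a single change can be read, and in this assay 3-chlorophenyl in place of 3,4-difluorophenyl gives an 8.8-fold lower number from compound 2 to compound 3 (0.94 log units; beyond the scatter). Both groups are six-membered aromatic rings of carbon only, so this place responds strongly to a change in the halogens alone. Nothing at hand accounts for the size of this step.

As far as these compounds go, whether chlorine itself carries the step, or the halogen pattern as a whole, stays open. A 3-fluorophenyl or 3-bromophenyl group would separate the two.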